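A Cyanomethyl Oxime Ether in Place of the Trifluoromethyl Oxime

A few compounds are considered here, and "the series" means these few. Any claim that something is new, unique, unknown or untested is made for them only; others in the source may bear on it.

For the measured compounds named here, compound 2 `O/N=C(/c1ccc(Sc2cc(F)cc(C3CCOCC3)c2)cc1)C(F)(F)F` gives 280 nM in a functional assay (blood) for inhibition, with Homo sapiens as the target (on this read-out lower numbers stand for stronger inhibition and higher numbers for weaker inhibition), the higher of the two numbers measured so far. Going by the values given here, compound 1 `O/N=C/c1ccc(Sc2cc(F)cc(C3CCOCC3)c2)cc1` gives 120 nM in this assay, and the single measured step is a 2.3-fold higher number from compound 1 to compound 2 (0.37 log units; beyond the scatter). Compound 3 `C/C(=N\OCC#N)c1ccc(Sc2cc(F)cc(C3CCOCC3)c2)cc1` is the next compound to be measured; it differs from compound 2 as follows: a group of 7 heavy atoms (4 carbon, 2 nitrogen, 1 oxygen; no ring) in place of a group of 7 heavy atoms (2 carbon, 1 nitrogen, 1 oxygen, 3 fluorine; no ring), on an aromatic carbon. Among the compounds with values here, no measured step changes this aromatic carbon in the same way, so the step from compound 1 to compound 2 bears on it only loosely, showing that exchanging the group on this aromatic carbon moved the number modestly. Compound 3 is therefore expected to stay near compound 2, with any step within or only slightly beyond the scatter, and the estimated step is a 1.4-fold lower number from compound 2 to compound 3 (0.15 log units; within the scatter). For compound 3 the estimate in this assay is 200 nM, with a range from 60 nM to 700 nM.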

Compound 3, half-maximal inhibitory concentration: 20 nM
Beside the measured number, compound 3's estimate is 10-fold (1.00 log units) above it, outside the stated range (below it).
By their numbers in this assay, from the lowest: compound 3; then compound 1; then compound 2.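

For the compounds shown here, replacing the trifluoromethyl oxime with the cyanomethyl oxime ether gives a 14-fold lower number from compound 2 to compound 3 (1.15 log units; beyond the scatter) in this assay and shows that this aromatic carbon can carry a large gain, which the one earlier step, a rise in the number, gave no sign of. The same group also beats the plain oxime, with a 6.0-fold lower number from compound 1 to compound 3 (0.78 log units; beyond the scatter) as the result, so the gain does not merely undo the loss seen with the trifluoromethyl oxime. Nothing measured here accounts for the gain.

The entering group differs from both earlier groups in more than its nitrile, so the compounds shown do not tell which part of it matters. A methyl oxime ether without the nitrile, or a longer chain ending in a nitrile, would separate these parts.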